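The source may hold more compounds than are shown below. What is called first, only, known or untested is meant among the compounds shown, and "the series" means these compounds.

Of the compounds shown here, two built on the shared core have been measured in an assay on isolated protein for displacement of a labelled ligand from Gonadotropin-releasing hormone receptor (Rattus norvegicus); on this read-out higher numbers stand for weaker inhibition and lower numbers for stronger inhibition. Compound 1 `CCc1cc(CN2CCN(c3cccc4[nH]c(-c5ccc(C(C)(C)C)cc5)nc34)CC2)n(C)n1` gives 250 nM, and compound 2 `CCc1nc(CN2CCN(c3cccc4[nH]c(-c5ccc(C(C)(C)C)cc5)nc34)CC2)cn1C` gives 78 nM. Among the measured compounds shown here, the single step between them, a 3.2-fold lower number from compound 1 to compound 2 (0.51 log units; beyond the scatter), put 2-ethyl-1-methyl-1H-imidazol-4-yl in place of 3-ethyl-1-methyl-1H-pyrazol-5-yl on a saturated chain carbon bound to an amine nitrogen in a ring. For the measured compounds named here, compound 2 thus stands lowest of the two numbers, with compound 1 as its only neighbour at the higher value.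

Compound 3 `CCCn1c(CC)nc(C)c1CN1CCN(c2cccc3[nH]c(-c4ccc(C(C)(C)C)cc4)nc23)CC1` is the next compound and has not yet been measured. It differs from compound 2 in that (2-ethyl-4-methyl-1-propyl-1H-imidazol-5-yl in place of 2-ethyl-1-methyl-1H-imidazol-4-yl on a saturated chain carbon bound to an amine nitrogen in a ring). Going by the values given here, the only measured step, from compound 1 to compound 2, swapped one heteroaromatic ring for another; it does not touch the methyl and propyl groups that set compound 3 apart, so its bearing here is indirect. Among the compounds with values here, no measured pair shows such groups added to a ring already in place. In this assay the step expected for compound 3 is a 1.4-fold higher number from compound 2 to compound 3 (0.15 log units; within the scatter), with the direction left open. The estimate for compound 3 is 110 nM, within a range from 35 nM to 350 nM.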

Compound 3, half-maximal inhibitory concentration: 120 nM
Compound 3: the middle estimate sits 1.1-fold (0.04 log units) below what was measured; the measured number falls inside the stated range.
By their numbers in this assay, from the lowest: compounds 2 and 3 (each within the scatter of the next); then compound 1.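

In this assay, the position on a saturated chain carbon bound to an amine nitrogen in a ring accepts 2-ethyl-4-methyl-1-propyl-1H-imidazol-5-yl, with 11 heavy atoms against 8 in 2-ethyl-1-methyl-1H-imidazol-4-yl, and the added atoms bring no change that can be told from the scatter: a 1.5-fold higher number from compound 2 to compound 3 (0.19 log units; within the scatter). The other new step, a 2.1-fold lower number from compound 1 to compound 3 (0.32 log units; beyond the scatter), means that both imidazolyl groups shown now give lower numbers than the 3-ethyl-1-methyl-1H-pyrazol-5-yl group of compound 1, a pattern that no compound here goes against but that rests on only these three. Nothing measured here gives a reason for these numbers.

Compound 3 differs from compound 2 in the added methyl, the propyl in place of methyl and the point of attachment all at once, so the share of each in the step cannot be separated. From the compounds shown here alone, whether a carboxylic acid, an amine or a chain longer than propyl on the imidazole ring would keep the number in this range remains open.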